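This account rests on a few compounds, and the source may have more. Where it says the series, first, only, none or still open, it means among the compounds named here.

Measured so far in a physicochemical assay for solubility, read by HPLC, using the shake flask method, in phosphate buffer, with a stated time of 20 h, at pH 6.5; a lower number here means a less soluble compound, a higher number a more soluble compound:
Compound 1 `O=C1CN(c2nccc3[nH]c(-c4ccc(F)c(F)c4)nc23)CCN1` gives < 5000 nM as a limit of the assay, not a number.
Compound 2 `Fc1ccc(-c2nc3c(C4CCNCC4)nccc3[nH]2)cc1F` gives 200000 nM as a number.
Compound 3 `CN(C)C1CCN(c2nccc3[nH]c(-c4cccc(OC(F)(F)F)c4)nc23)CC1` gives 180000 nM as a number.

In this assay compound 3 at 180000 nM and compound 2 at 200000 nM sit within the usual scatter of each other. Compound 4 `CN1CCN(CC2CCN(c3nccc4[nH]c(-c5cccc(OC(F)(F)F)c5)nc34)CC2)CC1` differs from compound 3 in one place: it has (4-methylpiperazin-1-yl)methyl in place of dimethylamino on a saturated ring carbon.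

Within the data shown here, no measured step changes this group. Among the measured compounds shown here, the only measured step is large, an at least 40-fold higher number from compound 1 to compound 2 (1.60 log units; beyond the scatter), but it swaps a different group on an aromatic carbon. It therefore gives no direction here and serves only as a warning that one swap can move the number a long way. The expectation starts from compound 3 at 180000 nM and, with a wide margin, foresees no shift beyond the scatter in either direction. The expected change is a 1.2-fold lower number from compound 3 to compound 4 (0.08 log units; within the scatter) in this estimate. For compound 4 the estimated value is 150000 nM with an expected range of 50000 nM to 400000 nM in this assay.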

Compound 4, solubility: 200000 nM
Estimate against measurement, compound 4: 1.3-fold (0.12 log units) below, within the range that was stated.
By their numbers in this assay, from the lowest: compounds 3, 2 and 4 (each within the scatter of the next). At a limit, below all of these: compound 1.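

In this assay, putting (4-methylpiperazin-1-yl)methyl in place of dimethylamino on a saturated ring carbon gives a 1.1-fold higher number from compound 3 to compound 4 (0.05 log units; within the scatter), so the two compounds read alike. Among these compounds, the earlier compounds held only one measured step, a large one on an aromatic carbon, whereas this is the first measured swap at this saturated ring carbon. Here a much larger group, carrying a six-membered non-aromatic ring of its own, leaves the reading where it was, and nothing at hand explains why.

On these data alone, what a carboxylic acid or a plain longer carbon chain without nitrogen would give at this ring carbon remains open. All the groups shown here at this place carry an amine, so how far this tolerance extends beyond amines also remains open.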